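Nitro in Place of Methoxy: Cytotoxicity Unchanged?

This account rests on a few compounds, and the source may have more. Where it says the series, first, only, none or still open, it means among the compounds named here.

Compound 2 `COc1ccccc1C1SCC(=O)N1CCN1CCCCC1` and compound 1 `O=C1CSC(c2ccc(O)cc2)N1CCN1CCCCC1` share one core and differ in the group on the aromatic ring. In an ADME assay on Vero cells (Chlorocebus sabaeus) for cytotoxicity, read by neutral red uptake, tested at 3150 ug/mL (on this read-out lower numbers stand for a stronger effect and higher numbers for a weaker effect at the one concentration tested), compound 2 gives 5%, and compound 1 gives 10%; the two numbers lie within the scatter of each other, so neither stands apart. Compound 3 `O=C1CSC(c2ccccc2[N+](=O)[O-])N1CCN1CCCCC1` is not yet measured. Its change from compound 2 is nitro in place of methoxy on an aromatic carbon. Going by the values given here, no measured pair shows what such a change does here, so the step from compound 2 to compound 3 is expected to stay within the scatter, a number 3 percentage points higher from compound 2 to compound 3 (within the scatter). For compound 3 in this assay an estimate of 8% is expected, between 0% and 30%.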

Compound 3, a percentage reported as activity, at one concentration (the size of the read-out at that concentration, not a potency): 30%
Compound 3: the middle estimate sits 22 percentage points below what was measured; the range from low to high includes it.
By their numbers in this assay, from the lowest: compounds 2 and 1 (each within the scatter of the next); then compound 3.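

In this assay, nitro in place of methoxy on this aromatic carbon, ortho to a large group, gives a number 25 percentage points higher from compound 2 to compound 3 (beyond the scatter), which here means a weaker effect at the one concentration tested. This is the first step among these compounds that stands clear of the scatter, so the group at this position can matter. Nothing available explains why the number moves.

Going by these compounds, whether an amine or a carboxylic acid on this same carbon would stay close to methoxy or move like nitro remains open.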